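A few compounds are considered here, and "the series" means these few. Any claim that something is new, unique, unknown or untested is made for them only; others in the source may bear on it.

Working notes on the series.

Compound 3 `CC(=O)N1CC[C@H](Oc2cncc(N3C(=O)c4ccc(Cl)cc4C3(C)C)c2)C1` gives the lowest number of the three in an assay on cells for inhibition of cytochrome P450 11B2, mitochondrial (Homo sapiens), read by HTRF (a lower number here means a stronger inhibitor, a higher number a weaker inhibitor), at 7 nM. Compound 1 `CC(=O)N1CC[C@@H](Oc2cncc(N3C(=O)c4ccc(Cl)cc4C3(C)C)c2)C1` gives 11 nM in this assay, and the step of a 1.6-fold lower number from compound 1 to compound 3 (0.20 log units; within the scatter) stays within the scatter, which fits (the fact that compounds 1 and 3 differ only in the configuration as drawn). Compound 2 `CC1(C)c2cc(Cl)ccc2C(=O)N1c1cccnc1` gives 108 nM in this assay, so the step of a 15-fold lower number from compound 2 to compound 3 (1.19 log units; beyond the scatter) is the large one in the set, and the reverse removal, a 9.8-fold higher number from compound 1 to compound 2 (0.99 log units; beyond the scatter), is modest but clear.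

Compound 4 `CCS(=O)(=O)NCc1cncc(N2C(=O)c3ccc(Cl)cc3C2(C)C)c1` is not yet measured in this assay. The change from compound 3 is a group of 7 heavy atoms (3 carbon, 1 nitrogen, 2 oxygen, 1 sulfur; no ring) in place of a group of 9 heavy atoms (6 carbon, 1 nitrogen, 2 oxygen; one five-membered non-aromatic ring with 1 hetero atom), on an aromatic carbon. The two steps that bear on it, a 15-fold lower number from compound 2 to compound 3 (1.19 log units; beyond the scatter) and a 9.8-fold higher number from compound 1 to compound 2 (0.99 log units; beyond the scatter), both show that occupying this aromatic carbon with a group of similar size and acceptor count matters for the number; compound 4 keeps a substituent there, though a different one, without a ring and carrying a hydrogen-bond donor. A step of modest size in this assay, toward a higher number, is therefore expected, smaller than the full loss seen on going to compound 2. For compound 4 the estimate in this assay is 25 nM, with a range from 8 nM to 80 nM, meaning an expected step of a 3.6-fold higher number from compound 3 to compound 4 (0.55 log units; beyond the scatter).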

Compound 4, half-maximal inhibitory concentration: 92 nM
Compound 4: middle estimate off by 3.7-fold (0.57 log units), on the low side; the measured number lies above the stated range.
By their numbers in this assay, from the lowest: compounds 3 and 1 (each within the scatter of the next); then compounds 4 and 2 (each within the scatter of the next).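

In this assay, occupying this aromatic carbon is not enough in itself: a 13-fold higher number from compound 3 to compound 4 (1.12 log units; beyond the scatter) and an 8.4-fold higher number from compound 1 to compound 4 (0.92 log units; beyond the scatter) are both beyond the scatter, whereas ((ethylsulfonyl)amino)methyl in place of hydrogen gives a 1.2-fold lower number from compound 2 to compound 4 (0.07 log units; within the scatter), which is within the scatter. The gain seen earlier at this carbon therefore belongs, among the compounds shown, to the ring-bearing group shared by compounds 1 and 3, and not to any substituent of similar size. No measurement given here explains the difference between the two groups.

Going by these compounds, it remains open whether the ether oxygen, the five-membered ring or the acetyl group carries that gain. A methoxy group, an unacylated ring amine or an acetamidomethyl chain at this carbon would help separate these parts.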